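Series notes: hexyloxy to benzylsulfanyl on the shared core

A few compounds are considered here, and "the series" means these few. Any claim that something is new, unique, unknown or untested is made for them only; others in the source may bear on it.

Compound 1 `Nc1nc(NC2CCCC2)c2ncn(/C=C3/CC3(CO)CO)c2n1` carries a cyclopentylamino group on the shared core. In an ADME assay on Akata cells (Homo sapiens) for cytotoxicity, with a stated time of 7 days (a lower number here means that less compound is tolerated, a higher number that more compound is tolerated), compound 1 gives only the limit > 20000 nM. Compound 2 `CCOc1nc(N)nc2c1ncn2/C=C1/CC1(CO)CO` has ethoxy in place of cyclopentylamino on an aromatic carbon, and in this assay compound 2 likewise gives only the limit > 20000 nM. Compound 3 `CCCCCCOc1nc(N)nc2c1ncn2/C=C1/CC1(CO)CO` has hexyloxy in place of cyclopentylamino on an aromatic carbon, and in this assay compound 3 again gives only the limit > 20000 nM. Compound 3 therefore stands exactly where the rest of the series stands: the limit of > 20000 nM in this assay, at which 3 of the 3 values shown sit. No order among compound 1, compound 2 and compound 3 can be read, as every value is a limit.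

Compound 4 `Nc1nc(SCc2ccccc2)c2ncn(/C=C3/CC3(CO)CO)c2n1` differs from compound 3 in one place: benzylsulfanyl in place of hexyloxy on an aromatic carbon. The measured steps at this aromatic carbon are a step that the two limits leave unreadable from compound 1 to compound 2, a step that the two limits leave unreadable from compound 1 to compound 3 and a step that the two limits leave unreadable from compound 2 to compound 3; none has a readable size, since the limit of > 20000 nM in this assay, at which 3 of the 3 values shown sit, holds both ends of each. They give no sign that changing the group at this position moves the tolerated concentration out of the limit region, so for compound 4 no step beyond the scatter is expected in this assay, and a further limit is the likely outcome. The expected step is a step that the limit leaves unreadable from compound 3 to compound 4. Compound 4 is estimated at 30000 nM, within 12000 nM to 100000 nM.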

Compound 4, half-maximal cytotoxic concentration: > 20000 nM
Compound 4: a limit, no number (the forecaster's own chance of this, stated with the estimate: 75%); the middle value lies beyond the limit too.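

Compound 4 also returns only a limit in this assay, so none of its steps from compound 1, compound 2 or compound 3 can be read: the limit of > 20000 nM in this assay, at which 4 of the 4 values shown sit. The compounds shown leave open whether any group at this aromatic carbon brings the tolerated concentration out of the limit region, and how cyclopentylamino, ethoxy, hexyloxy and benzylsulfanyl rank against one another.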